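Chloro for Methoxy at the Ortho Position: Expected Tolerability

The source may report more compounds than this note shows. Statements on the series, on what has been measured and on what is new or still open speak of the compounds shown alone.

The two measured compounds share one core. Compound 1 `Cc1cc(/C=C/C#N)cc(C(C)C)c1Nc1ccnc(Nc2ccc(C#N)cc2)n1` carries an isopropyl group on the aromatic carbon in question, and in an ADME assay on MT4 cells (Homo sapiens) for cytotoxicity, with a stated time of 3 days (a lower number here means that less compound is tolerated, a higher number that more compound is tolerated), compound 1 gives 11800 nM. Going by the values given here, compound 2 `COc1cc(/C=C/C#N)cc(C)c1Nc1ccnc(Nc2ccc(C#N)cc2)n1` has methoxy there instead, and in this assay compound 2 gives 633 nM, the lowest of the two numbers; its only neighbour is compound 1, reached by a 19-fold lower number from compound 1 to compound 2 (1.27 log units; beyond the scatter). Compound 3 `Cc1cc(/C=C/C#N)cc(Cl)c1Nc1ccnc(Nc2ccc(C#N)cc2)n1` is the next variation at the same site: chloro in place of methoxy on an aromatic carbon. Among the compounds with values here, only the step from isopropyl to methoxy at this carbon has been measured, and it was large; no measured step involves chloro, so the direction for chloro rests on that single precedent alone. Compound 3 is therefore estimated at 2000 nM, somewhere between 500 nM and 9000 nM. This estimate corresponds to a 3.2-fold higher number from compound 2 to compound 3 (0.50 log units; beyond the scatter) and is expected to be uncertain.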

Compound 3, half-maximal cytotoxic concentration: 2610 nM
Estimate against measurement, compound 3: 1.3-fold (0.12 log units) below; measured number inside the range.
By their numbers in this assay, from the lowest: compound 2; then compound 3; then compound 1.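

In this assay the change from methoxy to chloro gives a 4.1-fold higher number from compound 2 to compound 3 (0.62 log units; beyond the scatter) and so moves the number back up, while the change from isopropyl to chloro gives a 4.5-fold lower number from compound 1 to compound 3 (0.66 log units; beyond the scatter) and shows that chloro does not restore the isopropyl level. Going by these compounds alone, the single large step known before is thus divided into two modest ones, and the three groups now fall in a graded order at this carbon, with methoxy lowest, chloro in the middle and isopropyl highest. Nothing measured here explains that order.

The compounds shown leave open where a bromo group, an ethyl group or an amine at this carbon would fall in that order. They also leave open whether the same order would hold on a different core.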